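The source may report more compounds than this note shows. Statements on the series, on what has been measured and on what is new or still open speak of the compounds shown alone.

Compound 1 `CCOC(=O)c1cn(-c2c([N+](=O)[O-])ncn2C)nn1` gives > 376000 nM as a limit
Compound 2 `CCCCCc1ccc(-c2cn(-c3c([N+](=O)[O-])ncn3C)nn2)cc1` gives > 350000 nM as a limit

Compound 1 stands at > 376000 nM in an ADME assay on HepG2 cells (Homo sapiens) for cytotoxicity, read by WST assay, with a stated time of 24 h (a higher number here means a weaker inhibitor of growth, a lower number a stronger inhibitor of growth), and this value is only a limit. Compound 2 stands at > 350000 nM and this value is also only a limit. For the measured compounds named here, no measured step connects the two compounds. Compound 3 `Cn1cnc([N+](=O)[O-])c1-n1cc(C2CC2)nn1` differs from compound 1 by cyclopropyl in place of ethoxycarbonyl on an aromatic carbon with cyclopropyl in place of ethoxycarbonyl on an aromatic carbon. With both measured compounds at a limit, no change beyond the scatter is expected in this assay and the estimated step that the limit leaves unreadable from compound 1 to compound 3 is expected to be small. Compound 3 is expected at 380000 nM with an estimated range running from 150000 nM to 450000 nM at its upper end.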

Compound 3, concentration for 50% growth inhibition: > 427000 nM
Compound 3: a limit, no number; the forecaster's own chance of this, stated with the estimate: 80%; middle value at least 1.1-fold (0.05 log units) away from the limit.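

Compound 1 and compound 3 both stand only at limits in this assay, and the step between them cannot be read. The compounds shown leave open what the read-out, if any could be obtained, would be for any of them.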